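Adding Chloro to the Core of Compound 3

The source may report more compounds than this note shows. Statements on the series, on what has been measured and on what is new or still open speak of the compounds shown alone.

Compound 3 `O=C1Nc2ccccc2/C1=C\c1c(Cl)n(CCCc2ccccc2)c2ccccc12` gives 67600 nM in a functional assay on cells (Cancer cell lines, Homo sapiens) for cytotoxicity, with a stated time of 48 h (a lower number here means a stronger inhibitor of growth, a higher number a weaker inhibitor of growth), the second highest of the three numbers measured. For the measured compounds named here, its nearest neighbour is compound 1 `O=C1Nc2ccccc2/C1=C\c1c(Cl)n(Cc2ccccc2)c2ccccc12`, which gives 70800 nM; the only single-point step measured, a 1.0-fold lower number from compound 1 to compound 3 (0.02 log units; within the scatter), lies within the scatter. Furthest away is compound 2 `COc1cc2c(/C=C3/C(=O)Nc4ccc(Cl)cc43)c(Cl)n(Cc3cc(OC)c(OC)c(OC)c3)c2cc1C`, which gives 7240 nM and carries several changes at once, among them a chloro on its core.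

Compound 4 `O=C1Nc2ccc(Cl)cc2/C1=C\c1c(Cl)n(CCCc2ccccc2)c2ccccc12` differs from compound 3 by chloro in place of hydrogen on an aromatic carbon, on an aromatic carbon of a six-membered aromatic ring of carbon only, part of a fused system of two rings. Going by the values given here, no measured step isolates this change; the step from compound 1 to compound 3 concerns a different part of the molecule, and compound 2 mixes the chloro with other substituents. The expectation for compound 4 is therefore a small step at most, estimated as a 1.5-fold lower number from compound 3 to compound 4 (0.18 log units; within the scatter), leaning toward a lower number. Compound 4 is estimated at 45000 nM, within a range from 15000 nM to 120000 nM.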

Compound 4, concentration for total growth inhibition: 9770 nM
Compound 4: middle estimate off by 4.6-fold (0.66 log units), on the high side, and the stated range ends above it.
By their numbers in this assay, from the lowest: compounds 2 and 4 (each within the scatter of the next); then compounds 3 and 1 (each within the scatter of the next).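

In this assay, chloro in place of hydrogen on an aromatic carbon of the six-membered aromatic ring of carbon only gives a 6.9-fold lower number from compound 3 to compound 4 (0.84 log units; beyond the scatter) and is the only single-point step shown that lies beyond the scatter. The earlier step, a 1.0-fold lower number from compound 1 to compound 3 (0.02 log units; within the scatter), changed the chain on the aromatic nitrogen and stayed within the scatter, so this position on the core is the one place where a single change is seen to move the number. No measured evidence here accounts for this step.

Going by these compounds, whether fluoro, bromo, methoxy or an amine at this position would give a step of similar size remains open. So does whether the same chloro would give a comparable step on compound 1, with its different chain.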